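Thioether Aryl Swap on Compound 1

The source may hold more compounds than are shown below. What is called first, only, known or untested is meant among the compounds shown, and "the series" means these compounds.

Three compounds of this series have numbers in a functional assay on HeLa cells (Homo sapiens) for inhibition, read by CCK-8 assay, with a stated time of 72 h, tested at 8 uM; a higher number here means more inhibition of growth at the concentration tested, a lower number less inhibition of growth. Compound 1 `Cc1ccc(SCc2ccc(/C=C/C(=O)Nc3ccccc3N)cc2)cc1` gives 21.7%, the lowest of the three. Compound 3 `Cc1ccc(SCc2ccc(C(=O)Nc3ccccc3N)cc2)cc1` gives 79.2%, and compound 2 `Nc1ccccc1NC(=O)c1ccc(CSc2nccc(C(F)(F)F)n2)cc1` gives 83.4%; each of these stands beyond the scatter above compound 1, while the two of them lie within the scatter of each other. Among the measured compounds shown here, compounds 2 and 3 each differ from compound 1 in more than one place, so no single step between measured compounds is available.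

Compound 4 `Nc1ccccc1NC(=O)/C=C/c1ccc(CSc2ccc(C(F)(F)F)cn2)cc1` has not yet been measured. It differs from compound 1 in one place: 5-(trifluoromethyl)pyridin-2-yl in place of 4-methylphenyl on a sulfur. Compound 2 and compound 3 carry groups on the sulfur of this same kind and show numbers within the scatter of each other, but both also differ from compound 1 elsewhere, so the comparison is only indirect. The step is expected to be upward and of moderate size, a number 16.3 percentage points higher from compound 1 to compound 4 (beyond the scatter), because compound 1 sits at 21.7% with room above it. Compound 4 is estimated at 38%, with a range from 15% to 65%.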

Compound 4, percent growth inhibition at one concentration: 6.82%
Beside the measured number, compound 4's estimate is 31.2 percentage points above it; measured number outside the range, below it.
By their numbers in this assay, from the lowest: compound 4; then compound 1; then compounds 3 and 2 (each within the scatter of the next).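

In this assay, among the compounds shown here, the swap on the sulfur reads directly as a number 14.9 percentage points lower from compound 1 to compound 4 (beyond the scatter) and gives the first one-place comparison at this position. It shows that, on the core of compound 1, the group on the sulfur is not silent: 5-(trifluoromethyl)pyridin-2-yl brings no gain over 4-methylphenyl, and compound 4 gives 6.82% in this read-out. Nothing at hand explains the direction or size of this step.

The swap changes the ring atoms and the substituent together, so the step cannot be assigned to either one; a plain pyridin-2-yl or a 4-(trifluoromethyl)phenyl on the same sulfur would separate them. Also open, on these data alone, is how this position responds to groups of another kind, such as an aryl ring carrying an amine or a carboxylic acid.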